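The source may hold more compounds than are shown below. What is called first, only, known or untested is meant among the compounds shown, and "the series" means these compounds.

Measured so far in a functional assay on MCF7 cells (Homo sapiens) for antiproliferative activity, read by sulforhodamine B assay, with a stated time of 72 h; on this read-out higher numbers stand for weaker inhibition and lower numbers for stronger inhibition:
- compound 1 `COc1ccc(/C=C2\CCC=CC2=O)cc1` at 2570 nM
- compound 2 `O=C1C=CCC/C1=C\c1ccc(OC(F)(F)F)cc1` at 1040 nM
- compound 3 `COc1ccc(/C=C2\CCC=CC2=O)c(C)c1` at 1840 nM

Compound 1 sits at the high end of these numbers, within the scatter of compound 3, and only compound 2 lies clearly lower. Compound 4 `COc1ccc(/C=C2\CCC=CC2=O)cc1[N+](=O)[O-]` differs from compound 1 by nitro in place of hydrogen on an aromatic carbon and so carries nitro in place of hydrogen on an aromatic carbon, ortho to a methoxy group. Among the measured compounds shown here, two measured steps bear on this. One is a 1.4-fold lower number from compound 1 to compound 3 (0.15 log units; within the scatter) for methyl in place of hydrogen on an aromatic carbon. The other is a 2.5-fold lower number from compound 1 to compound 2 (0.39 log units; beyond the scatter) for trifluoromethyl in place of methyl on an oxygen. Neither step involves nitro, so in this assay only a small move to lower numbers is expected, possibly within the scatter. The expected step is a 1.6-fold lower number from compound 1 to compound 4 (0.21 log units; within the scatter) on this reasoning. For compound 4 the estimated value is 1600 nM with an expected range of 700 nM to 3600 nM in this read-out.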

Compound 4, half-maximal inhibitory concentration: 1680 nM
Beside the measured number, compound 4's estimate is 1.1-fold (0.02 log units) below it, and the stated range covers the measured number.
By their numbers in this assay, from the lowest: compounds 2, 4, 3 and 1 (each within the scatter of the next, the first and the last beyond it).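

In this assay, nitro in place of hydrogen on an aromatic carbon, ortho to a methoxy group, gives a 1.5-fold lower number from compound 1 to compound 4 (0.18 log units; within the scatter) and so leaves the number within the scatter of compound 1. Among the compounds shown here, this is the first group with nitrogen, and the position tolerates it without a clear change in either direction. No data here account for the size of this step.

The compounds shown leave open whether an amine or a carboxylic acid at this position would move the number beyond the scatter.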